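From 4-fluorophenyl to 4-bromophenyl: a single atom swapped

The source may hold more compounds than are shown below. What is called first, only, known or untested is meant among the compounds shown, and "the series" means these compounds.

In a functional assay on HepG2 cells (Homo sapiens) for inhibition, read by MTT assay, with a stated time of 72 h (a lower number here means a stronger inhibitor, a higher number a weaker inhibitor), compound 1 (`Cc1ccc(-c2nnc(SCCCN3CCN(c4nc5ccccc5s4)CC3)o2)cc1`) gives 96700 nM and compound 2 (`Fc1ccc(-c2nnc(SCCCN3CCN(c4nc5ccccc5s4)CC3)o2)cc1`) gives 234000 nM, so compound 2 has the higher number of the two and is the weaker inhibitor. Compound 3 (`Brc1ccc(-c2nnc(SCCCN3CCN(c4nc5ccccc5s4)CC3)o2)cc1`) keeps the shared core but carries bromo in place of fluoro on an aromatic carbon, para to a large group: bromo in place of fluoro on an aromatic carbon.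

Among the compounds with values here, only one measured step bears on this place: a 2.4-fold higher number from compound 1 to compound 2 (0.38 log units; beyond the scatter), with fluoro in place of methyl. Within the data shown here, that step is modest, and no bromo compound has been measured yet, so it is only a rough guide. Removing the fluoro may undo part of that rise, so a modest move towards a lower number is expected in this assay. The estimated step is a 1.7-fold lower number from compound 2 to compound 3 (0.22 log units; within the scatter). For compound 3 the estimated value is 140000 nM, with an expected range from 60000 nM to 280000 nM.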

Compound 3, half-maximal inhibitory concentration: 103000 nM
Compound 3: the middle estimate sits 1.4-fold (0.13 log units) above what was measured, within the range that was stated.
By their numbers in this assay, from the lowest: compounds 1 and 3 (each within the scatter of the next); then compound 2.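

In this assay, this position is not indifferent to which halogen it carries: bromo in place of fluoro gives a 2.3-fold lower number from compound 2 to compound 3 (0.36 log units; beyond the scatter), about as large as the earlier step from methyl to fluoro. The bromo compound also lands level with the methyl compound, with a 1.1-fold higher number from compound 1 to compound 3 (0.03 log units; within the scatter), so compound 1 and compound 3 cannot be told apart, and among these three groups only the fluoro of compound 2 stands out, as the weakest inhibitor. Nothing measured here accounts for why fluoro differs from the other two groups.

As far as these compounds go, it remains open whether a chloro, a methoxy or an amine at this position would sit with compound 1 and compound 3 or with compound 2. The same goes for whether this order of groups would hold if another part of the shared core were changed.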